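The source may report more compounds than this note shows. Statements on the series, on what has been measured and on what is new or still open speak of the compounds shown alone.

Compound 1 `Fc1ccc(Cn2cc(CSC(=S)N3CCNCC3)nn2)cc1` is one of a small group of compounds tested in a functional assay on ECa-109 cells (Homo sapiens) for inhibition, read by MTT assay, with a stated time of 72 h; on this read-out higher numbers stand for weaker inhibition and lower numbers for stronger inhibition. In this assay compound 1 gives > 128000 nM, which is a limit of the assay and not a number. Compound 2 `CC(C)(C)OC(=O)N1CCN(C(=S)SCc2cn(Cc3cc(=O)oc4cc(O)ccc34)nn2)CC1` has also been tested. In this assay compound 2 gives > 128000 nM, again a limit rather than a number. On the numbers shown, compound 1 therefore stands at the edge of what this assay can report, a position it shares with compound 2 (the limit of > 128000 nM in this assay, at which 2 of the 2 values shown sit).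

Compound 3 `S=C(SCc1cn(Cc2ccc(Cl)cc2)nn1)N1CCNCC1` has not yet been measured. It differs from compound 1 by chloro in place of fluoro on an aromatic carbon. Among the compounds with values here, no pair of measured compounds differing in a single place is available, so the effect of this change cannot be read from data. Because both measured compounds sit at the limit (the limit of > 128000 nM in this assay, at which 2 of the 2 values shown sit), compound 3 is expected to fall at or near that limit as well, so the expected step for compound 3 a step that the limit leaves unreadable from compound 1 to compound 3 is none beyond the scatter. Compound 3 is thus estimated at about 150000 nM, within a range of 60000 nM to 400000 nM.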

Compound 3, half-maximal inhibitory concentration: > 128000 nM
Compound 3: only a limit was reported; the forecaster's own chance of this, stated with the estimate: 85%; the middle value is on the limit's open side.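

In this assay compound 3 gives > 128000 nM which is a limit and not a number. No step can be read for chloro in place of fluoro between compound 1 and compound 3, because the values share one limit: the limit of > 128000 nM in this assay, at which 3 of the 3 values shown sit. The compounds shown leave open how strongly any of them inhibits, and whether this change matters at all.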